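The source may report more compounds than this note shows. Statements on the series, on what has been measured and on what is new or still open speak of the compounds shown alone.

Values measured in an ADME assay on the whole organism (strain Sprague-Dawley) for pharmacokinetics, with Rattus norvegicus as the target, read by LC-MS, using cassette dosing, at a dose of 0.5 mg/kg by the intravenous route (on this read-out lower numbers stand for slow clearance and higher numbers for fast clearance), so far:
- compound 1 `C[C@@]1(c2cc(NC(=O)c3coc(C(F)F)n3)ccc2F)C=C(CF)OC(N)=N1` gives 28.4 mL/min/kg
- compound 2 `COc1cnc(C(=O)Nc2ccc(F)c([C@]3(C)C=C(CF)OC(N)=N3)c2)cn1` gives 64.9 mL/min/kg
- compound 3 `C[C@@]1(c2cc(NC(=O)c3coc(CF)n3)ccc2F)C=C(CF)OC(N)=N1` gives 55 mL/min/kg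

Compound 3 cannot be separated from either of the other two compounds, with a 1.2-fold lower number from compound 2 to compound 3 (0.07 log units; within the scatter) and a 1.9-fold higher number from compound 1 to compound 3 (0.29 log units; within the scatter) as its two steps. Compound 4 `COc1cc(C#N)cnc1C(=O)Nc1ccc(F)c([C@]2(C)C=C(CF)OC(N)=N2)c1`, not yet measured, carries 5-cyano-3-methoxypyridin-2-yl in place of 2-(fluoromethyl)-1,3-oxazol-4-yl on a carbonyl carbon. Going by the values given here, that incoming group has no measured precedent in this set, so the nearest guidance comes from other changes on the same carbonyl carbon. One is a 1.2-fold lower number from compound 2 to compound 3 (0.07 log units; within the scatter) and the other, which goes further, is a 2.3-fold higher number from compound 1 to compound 2 (0.36 log units; beyond the scatter). With only these two modest precedents, no step beyond the scatter is expected in this assay for this change. The expected change is a 1.2-fold lower number from compound 3 to compound 4 (0.09 log units; within the scatter) by this estimate. For compound 4 the estimated clearance is 45 mL/min/kg, with an expected range from 22 mL/min/kg to 85 mL/min/kg (an estimate only).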

Compound 4, clearance: 36.6 mL/min/kg
Compound 4: middle estimate off by 1.2-fold (0.09 log units), on the high side; the measured number falls inside the stated range.
By their numbers in this assay, from the lowest: compounds 1, 4, 3 and 2 (each within the scatter of the next, the first and the last beyond it).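

On the carbonyl carbon, 5-cyano-3-methoxypyridin-2-yl brings a nitrile-bearing six-membered aromatic ring into this assay, and compound 4 stays within the scatter of all three earlier compounds (a 1.5-fold lower number from compound 3 to compound 4 (0.18 log units; within the scatter); a 1.8-fold lower number from compound 2 to compound 4 (0.25 log units; within the scatter); a 1.3-fold higher number from compound 1 to compound 4 (0.11 log units; within the scatter)). Going by these compounds alone, the only step beyond the scatter at this position remains the one between the two ends of the series (a 2.3-fold higher number from compound 1 to compound 2 (0.36 log units; beyond the scatter)), and compound 4 falls inside that span, so neither ring size nor the larger group sorts these compounds into separate levels. No measurement shown here explains these numbers.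

The compounds shown do not separate the nitrile from the methoxy within 5-cyano-3-methoxypyridin-2-yl. They also leave open whether an aromatic ring carrying an amine or a carboxylic acid on the same carbonyl carbon would step beyond the scatter.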